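Replacing an Aromatic Arm with a Small Oxygen Ring

The source may report more compounds than this note shows. Statements on the series, on what has been measured and on what is new or still open speak of the compounds shown alone.

Of the compounds shown here, three sharing one core have been measured in an assay on CHO cells for displacement of a labelled ligand from Substance-P receptor (Homo sapiens), in the presence of a further agent that is not named here; a lower number here means a stronger inhibitor, a higher number a weaker inhibitor. Compound 1 `C[C@@H](O[C@H]1CN2C(=O)C=C(c3ccc(NS(C)(=O)=O)cc3)CC2[C@@H]1c1ccc(F)cc1)c1cc(C(F)(F)F)cc(C(F)(F)F)c1` gives 54 nM. Compound 2 `COc1cc(C2=CC(=O)N3C[C@H](O[C@H](C)c4cc(C(F)(F)F)cc(C(F)(F)F)c4)[C@@H](c4ccc(F)cc4)C3C2)ccn1` gives 44 nM. Compound 3 `C[C@@H](O[C@H]1CN2C(=O)C=C(C3=CCC(O)CC3)CC2[C@@H]1c1ccc(F)cc1)c1cc(C(F)(F)F)cc(C(F)(F)F)c1` gives 13 nM. Compound 1 therefore carries the highest number of the three; compound 2 sits closest to it, with a 1.2-fold lower number from compound 1 to compound 2 (0.09 log units; within the scatter), and compound 3 furthest, with a 4.2-fold lower number from compound 1 to compound 3 (0.62 log units; beyond the scatter).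

Compound 4 `C[C@@H](O[C@H]1CN2C(=O)C=C(C3=CCOCC3)CC2[C@@H]1c1ccc(F)cc1)c1cc(C(F)(F)F)cc(C(F)(F)F)c1` has not yet been measured. It differs from compound 1 in one place: a group of 6 heavy atoms (5 carbon, 1 oxygen; one six-membered non-aromatic ring with 1 hetero atom) in place of a group of 11 heavy atoms (7 carbon, 1 nitrogen, 2 oxygen, 1 sulfur; one six-membered aromatic ring of carbon only), on a double-bonded ring carbon. Going by the values given here, two measured steps bear on this change. Exchanging the aromatic arm of compound 1 for another six-membered aromatic ring gave a 1.2-fold lower number from compound 1 to compound 2 (0.09 log units; within the scatter), a change within the scatter. Exchanging it for a six-membered non-aromatic ring gave a 4.2-fold lower number from compound 1 to compound 3 (0.62 log units; beyond the scatter), a modest gain. Compound 4 also carries a six-membered non-aromatic ring on the same double-bonded ring carbon, so a modest drop in number is expected in this assay, estimated as a 2.5-fold lower number from compound 1 to compound 4 (0.39 log units; beyond the scatter). Because of a 4.2-fold lower number from compound 1 to compound 3 (0.62 log units; beyond the scatter), compound 4 is expected to reach about 22 nM, with a likely range from 10 nM to 50 nM.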

Compound 4, half-maximal inhibitory concentration: 9.6 nM
For compound 4 the middle estimate is 2.3-fold (0.36 log units) above the measured one; the measured number lies below the stated range.
By their numbers in this assay, from the lowest: compounds 4 and 3 (each within the scatter of the next); then compounds 2 and 1 (each within the scatter of the next).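

In this assay, the non-aromatic arm of compound 4 clearly outperforms both aromatic arms, with a 5.6-fold lower number from compound 1 to compound 4 (0.75 log units; beyond the scatter) and a 4.6-fold lower number from compound 2 to compound 4 (0.66 log units; beyond the scatter), so the gain seen with compound 3 now recurs with a second non-aromatic ring on the same double-bonded ring carbon. The hydroxy group of compound 3 is also not required to reach this level: the arm of compound 4 has an oxygen within the ring and no hydrogen-bond donor, and the comparison gives a 1.4-fold lower number from compound 3 to compound 4 (0.13 log units; within the scatter). Nothing available explains why these two non-aromatic arms give lower numbers than the two aromatic arms.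

Going by these compounds, it remains open whether a ring nitrogen, as in a piperidine amine, could take the place of the ring oxygen of compound 4, and whether a fully saturated ring without the double bond would hold the same level. A carboxylic acid on the ring, a five-membered ring or an open methoxyethyl chain on this carbon would also test how far the trend extends beyond these four compounds.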